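Adding one methyl group to compound 1

The source may report more compounds than this note shows. Statements on the series, on what has been measured and on what is new or still open speak of the compounds shown alone.

In a functional assay on MCF7 cells (Homo sapiens) for cytotoxicity, read by MTT assay, with a stated time of 96 h (on this read-out lower numbers stand for stronger inhibition and higher numbers for weaker inhibition), compound 1 `COc1cc(C(=O)c2cn(-c3ccccc3)cc2-c2cccc([N+](=O)[O-])c2)cc(OC)c1OC` gives 50 nM and stands lowest of the three measured compounds, with compound 2 `COc1cccc(-c2cn(-c3ccccc3)cc2C(=O)c2cc(OC)c(OC)c(OC)c2)c1` at 180 nM and compound 3 `COc1ccc(Br)cc1-c1cn(-c2ccccc2)cc1C(=O)c1cc(OC)c(OC)c(OC)c1` at 2200 nM on the higher side. Compound 4 `COc1cc(C(=O)c2cn(-c3ccc(C)cc3)cc2-c2cccc([N+](=O)[O-])c2)cc(OC)c1OC` differs from compound 1 in one place, by methyl in place of hydrogen on an aromatic carbon in the change from phenyl to 4-methylphenyl: methyl in place of hydrogen on an aromatic carbon, para to a large group. The measured steps bear on this only indirectly. Both a 3.6-fold higher number from compound 1 to compound 2 (0.56 log units; beyond the scatter) (modest) and a 44-fold higher number from compound 1 to compound 3 (1.64 log units; beyond the scatter) (large) replace the 3-nitrophenyl group, and so does a 12-fold higher number from compound 2 to compound 3 (1.09 log units; beyond the scatter) (large) in going on from one replacement to another. These steps show that the numbers can move when that other group changes, but none of them tests the phenyl that changes here. With no evidence for a direction, no step beyond the scatter is expected in this assay and the estimated result is a 1.2-fold higher number from compound 1 to compound 4 (0.08 log units; within the scatter) for now. The expected value for compound 4 is 60 nM within an estimated range of 15 nM to 240 nM overall.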

Compound 4, half-maximal inhibitory concentration: 210 nM
Compound 4: the middle estimate sits 3.5-fold (0.54 log units) below what was measured, within the range that was stated.
By their numbers in this assay, from the lowest: compound 1; then compounds 2 and 4 (each within the scatter of the next); then compound 3.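

In this assay, methyl in place of hydrogen on the phenyl group brings a 4.2-fold higher number from compound 1 to compound 4 (0.62 log units; beyond the scatter). Among these compounds, the earlier steps all changed the 3-nitrophenyl group, so this is the first sign that the phenyl group also matters, and that one added carbon, para to a large group, is enough to move the number beyond the scatter. No measurement at hand explains why this step occurs.

A single compound cannot show whether any group at this place raises the number or whether methyl alone does so, and a fluorine, a methoxy group, an amine or a longer chain such as ethyl would help to separate the two. Also open, as far as these compounds go, is whether the same methyl would bring a similar step with the 3-methoxyphenyl group of compound 2 in place of the 3-nitrophenyl group.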